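The source may hold more compounds than are shown below. What is called first, only, known or untested is meant among the compounds shown, and "the series" means these compounds.

Measured so far:
compound 1, `Cc1ccc(CN(C)C(=O)c2nn(-c3ccc(F)cc3)c(OC[C@@H](O)C[C@@H](O)CC(=O)O)c2C(C)C)cc1` — 1250 nM
compound 2, `CC(C)c1c(C(=O)N(C)Cc2cccc(C(F)(F)F)c2)nn(-c2ccc(F)cc2)c1OC[C@@H](O)C[C@@H](O)CC(=O)O` — "not determined" (no result reported)

Within the data shown here, compound 1 holds the only number in a functional assay on L6 cells (Rattus norvegicus) for inhibition (a higher number here means a weaker inhibitor, a lower number a stronger inhibitor), where compound 1 gives 1250 nM. Compound 2 returned no result, so nothing stands beside compound 1 for comparison. Compound 3, `CC(C)c1c(C(=O)N(C)Cc2ccc(F)c(F)c2)nn(-c2ccc(F)cc2)c1OC[C@@H](O)C[C@@H](O)CC(=O)O`, remains to be measured; it differs from compound 1 by 3,4-difluorophenyl in place of 4-methylphenyl on a saturated chain carbon bound to an amide-type nitrogen. Among the measured compounds shown here, no step between measured compounds is available to calibrate this change. The expected step is therefore small, likely within the scatter and without a firm direction: a 1.0-fold lower number from compound 1 to compound 3 (0.02 log units; within the scatter). Compound 3 is estimated at 1200 nM, with a range from 400 nM to 4000 nM.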

Compound 3, half-maximal inhibitory concentration: 4570 nM
Compound 3: the middle estimate sits 3.8-fold (0.58 log units) below what was measured, and the stated range ends below it.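

In this assay, the benzyl position on the amide-type nitrogen proves sensitive to substitution: 3,4-difluorophenyl in place of 4-methylphenyl gives a 3.7-fold higher number from compound 1 to compound 3 (0.56 log units; beyond the scatter). Among these compounds, this is the first calibrated change, and it shows that this swap on the saturated chain carbon weakens inhibition rather than leaving it unchanged. No measured data on hand explain the shift. The compounds shown leave open whether a single fluorine, a 4-chlorophenyl or an unsubstituted phenyl at this place would retain the number of compound 1 (1250 nM).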